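Changing the Aromatic Group on the Amide Carbonyl

The source may report more compounds than this note shows. Statements on the series, on what has been measured and on what is new or still open speak of the compounds shown alone.

Of the compounds shown here, two have been tested so far. Compound 1 `O=C(NC1CCCCC1)NS(=O)(=O)N1CCC(CCNC(=O)c2csnn2)CC1` gives 19% in a functional assay on the whole organism (blood) with Rattus norvegicus as the target, with stated times of 24 h and 1 h, at a dose of 5 mg/kg by the intraperitoneal route; on this read-out higher numbers stand for a stronger effect at the one dose given and lower numbers for a weaker effect. Compound 2 `O=C(NC1CCCCC1)NS(=O)(=O)N1CCC(CCNC(=O)c2ccc3ccccc3n2)CC1` gives 11% in this assay, which is the lower of the two numbers, though the difference to compound 1 is within the usual scatter. Within the data shown here, the only step measured so far, a number 8 percentage points lower from compound 1 to compound 2 (within the scatter), also exchanges the group on the carbonyl carbon and changed little.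

Compound 3 `COc1ccc2nccc(C(=O)NCCC3CCN(S(=O)(=O)NC(=O)NC4CCCCC4)CC3)c2c1` has not yet been measured. The change from compound 2 to compound 3 is 6-methoxyquinolin-4-yl in place of quinolin-2-yl on a carbonyl carbon. Among the measured compounds shown here, since the one earlier exchange at this carbonyl carbon stayed within the scatter, the expected step of a number 3 percentage points higher from compound 2 to compound 3 (within the scatter) is likewise one of no clear size beyond the scatter in this assay. Compound 3 is therefore expected to give about 14%, within a range of 0% to 32%.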

Compound 3, a percentage reported as activity, at one dose (the size of the read-out at that dose, not a potency): 15%
Compound 3: the middle estimate sits 1 percentage points below what was measured, within the range that was stated.
By their numbers in this assay, from the lowest: compounds 2, 3 and 1 (each within the scatter of the next).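

Replacing one fused two-ring aromatic group with another that carries a methoxy group and is attached through a different ring position leaves the result in this assay within the scatter: a number 4 percentage points higher from compound 2 to compound 3 (within the scatter). Compared with the five-membered sulfur-containing group, the result is also within the scatter: a number 4 percentage points lower from compound 1 to compound 3 (within the scatter). Across these three aromatic groups, their differences in size and ring type therefore produce no clear separation at this one dose, and no supporting evidence bears on the reason for this.

On these data alone, it remains open whether a non-aromatic group, such as a butyl chain, would separate from these three compounds. The same question applies to an aromatic ring bearing a carboxylic acid or an amine on the carbonyl carbon.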